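Swapping a Meta Chloro for Cyano in a Tetralone Series

The compounds below may be only part of what the source reports. "The series", "measured", "known", "first", "only" and "open" are said of these compounds alone.

Compound 1 `O=C1CCCc2cc(OCc3cccc(Cl)c3)ccc21` stands lowest of the two compounds that have been measured in an assay on isolated protein for inhibition of Amine oxidase [flavin-containing] A (Homo sapiens), read by fluorescence and spectrophotometry, with a stated time of 30 min (on this read-out lower numbers stand for stronger inhibition and higher numbers for weaker inhibition), where compound 1 gives 207 nM. Its nearest companion is compound 2 `Cc1ccc(COc2ccc3c(c2)CCCC3=O)cc1`, which carries a methyl in place of the chloro and gives in this assay a value of 2090 nM, a number that sits well beyond the scatter above compound 1. Compound 3 `N#Cc1cccc(COc2ccc3c(c2)CCCC3=O)c1` has not yet been measured in this assay. It differs from compound 1 by a single change: cyano in place of chloro on an aromatic carbon, meta to a large group. For the measured compounds named here, no pair of measured compounds shows exactly this exchange, so the size of the step has to be guessed. The step from compound 1 to compound 3 is expected to be small, with a lean toward a somewhat higher number, as a 1.7-fold higher number from compound 1 to compound 3 (0.23 log units; within the scatter). For compound 3 the estimated value in this assay is 350 nM, with a range from 120 nM to 1200 nM.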

Compound 3, half-maximal inhibitory concentration: 24 nM
The estimate for compound 3 lay 15-fold (1.16 log units) above the measured number; the whole stated range lies above it.
By their numbers in this assay, from the lowest: compound 3; then compound 1; then compound 2.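

In this assay, the place on the aromatic ring that holds the chloro of compound 1 turns out to respond strongly to a change of group: cyano in place of chloro on an aromatic carbon, meta to a large group, gives an 8.6-fold lower number from compound 1 to compound 3 (0.94 log units; beyond the scatter) and so moves the number beyond the usual scatter. For the compounds shown here, the earlier pair could not show this, since compound 1 and compound 2 differ in more than one place, so this is the first clean reading of an exchange at this position, and chloro is not the group with the lowest number here. The entering cyano carries one hydrogen-bond acceptor where chloro carries none, but nothing at hand connects that count or any other feature of the group to the lower number.

The compounds shown leave open whether other groups at this same place, such as an amine, a carboxylic acid or a methoxy, would give lower or higher numbers than cyano. They also leave open whether cyano would give a step of similar size at another carbon of the ring or on a changed core.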